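This account rests on a few compounds, and the source may have more. Where it says the series, first, only, none or still open, it means among the compounds named here.

Measured so far in an assay on isolated protein for inhibition of serine/threonine-protein kinase D2 (Homo sapiens), read by mobility shift assay, tested at 30 uM; on this read-out lower numbers stand for less inhibition and higher numbers for more inhibition at the one concentration tested (going by the name of the read-out):
- compound 1 `COc1ccc(-c2cc3[nH]nc(N)c3c(=O)[nH]2)cc1` — 28%
- compound 2 `Cn1nc(N)c2c(=O)[nH]c(-c3ccccc3)cc21` — 14%

Compound 2 stands lowest of the two numbers; its nearest neighbour is compound 1, whose value lies higher by a margin that is beyond the usual scatter. For the measured compounds named here, the two compounds differ in more than one place, so no single step between them can be read off; the numbers only show that compound 1 gives 28% and compound 2 gives 14% in this assay.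

Compound 3 `COc1ccc(-c2cc3c(c(N)nn3C)c(=O)[nH]2)cc1` has not yet been measured. It differs from compound 2 by methoxy in place of hydrogen on an aromatic carbon.

Going by the values given here, no step between measured compounds carries this exact change on its own. With compound 1 giving 28% and carrying the same methoxy group, a modest rise is the working expectation, though an outcome within the scatter of compound 2 cannot be ruled out. The step from compound 2 to compound 3 is expected to be a number 10 percentage points higher from compound 2 to compound 3 (within the scatter). Compound 3 is estimated at 24%, with a range of 10% to 40%.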

Compound 3, a percentage reported as inhibition, at one concentration (the size of the read-out at that concentration, not a potency): 36%
Beside the measured number, compound 3's estimate is 12 percentage points below it; the measured number falls inside the stated range.
By their numbers in this assay, from the lowest: compound 2; then compounds 1 and 3 (each within the scatter of the next).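

In this assay, for the compounds shown here, methoxy in place of hydrogen on an aromatic carbon, para to a large group on a six-membered aromatic ring of carbon only, gives a number 22 percentage points higher from compound 2 to compound 3 (beyond the scatter), the first single-place change that can be read and one that lies beyond the scatter. Methyl in place of hydrogen on an aromatic nitrogen gives a number 8 percentage points higher from compound 1 to compound 3 (within the scatter), which lies within the scatter, so compound 1 and compound 3 cannot be told apart in this assay. No measurement at hand accounts for either step.

Whether the rise belongs to methoxy in particular remains open, since the series shown holds no other group at this place, such as hydroxyl, fluorine, an amine or the longer ethoxy chain. Also open, from the compounds shown here alone, is whether the methyl step on the nitrogen would read the same on a core carrying hydrogen rather than methoxy at this place.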